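Acylurea Thiazole Hydrazones: Swapping the Acyl Aryl Group

The source may hold more compounds than are shown below. What is called first, only, known or untested is meant among the compounds shown, and "the series" means these compounds.

Measured compounds:
compound 1 `CN(C(=O)NC(=O)c1c(F)cccc1F)c1nc(C(F)(F)F)c(C(=O)N/N=C/c2cccc(C(F)(F)F)c2)s1` — 27.9 ug/mL
compound 2 `Cc1nc(N(C)C(=O)NC(=O)c2c(F)cccc2F)sc1C(=O)N/N=C/c1cccc(C(F)(F)F)c1` — 31.6 ug/mL
compound 3 `CN(C(=O)NC(=O)c1c(F)cccc1F)c1nc(C(F)(F)F)c(C(=O)N/N=C/c2cc(C(F)(F)F)cc(C(F)(F)F)c2)s1` — 6.28 ug/mL

In a functional assay on HepG2 cells (Homo sapiens) for inhibition, read by MTT assay, with a stated time of 72 h (a lower number here means a stronger inhibitor, a higher number a weaker inhibitor), compound 1 gives 27.9 ug/mL, the second highest of the three numbers. The gap to compound 2, a 1.1-fold higher number from compound 1 to compound 2 (0.05 log units; within the scatter), lies within the scatter, while the gap to compound 3, a 4.4-fold lower number from compound 1 to compound 3 (0.65 log units; beyond the scatter), is a modest lowering. Compound 4 `CN(C(=O)NC(=O)c1cccc(C(F)(F)F)c1)c1nc(C(F)(F)F)c(C(=O)N/N=C/c2cccc(C(F)(F)F)c2)s1` differs from compound 1 in one place: 3-(trifluoromethyl)phenyl in place of 2,6-difluorophenyl on a carbonyl carbon. Neither measured step touches this carbonyl-bound ring; the step to compound 3 changes the hydrazone-bound ring instead. Without a step at this position, no change beyond the scatter is expected, and compound 4 is estimated at 25 ug/mL (range 10 ug/mL to 60 ug/mL), a step of a 1.1-fold lower number from compound 1 to compound 4 (0.05 log units; within the scatter).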

Compound 4, half-maximal inhibitory concentration: 5.79 ug/mL
Estimate against measurement, compound 4: 4.3-fold (0.64 log units) above, and the stated range ends above it.
By their numbers in this assay, from the lowest: compounds 4 and 3 (each within the scatter of the next); then compounds 1 and 2 (each within the scatter of the next).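

In this assay the aryl group on the carbonyl carbon proves not to be a silent position: 3-(trifluoromethyl)phenyl in place of 2,6-difluorophenyl gives a 4.8-fold lower number from compound 1 to compound 4 (0.68 log units; beyond the scatter) and moves the number beyond the scatter. Within the data shown here, the earlier steps changed other parts of compound 1, so this is the first reading at this carbonyl. No measured evidence here accounts for the step.

On these data alone, whether the change follows from gaining trifluoromethyl or from losing the two fluorines stays open. Also open, as far as these compounds go, are what a plain phenyl or an aminophenyl would give here, and whether the swap carries over to compound 2 or compound 3.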